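Para substituent swap on the shared core, calcium-flux series

The source may hold more compounds than are shown below. What is called first, only, known or untested is meant among the compounds shown, and "the series" means these compounds.

Compound 1 `COc1ccc(Cc2cc(-c3ccc(OC)cc3)nn(CC(=O)Nc3ccc(Br)cc3)c2=O)cc1` sits at the limit of a functional assay on HL-60 cells (Homo sapiens), read by calcium flux; a lower number here means that less compound is needed, a higher number that more compound is needed for the effect: in this assay compound 1 gives > 50000 nM, a limit rather than a number. Compound 2 `COc1ccc(Cc2cc(-c3ccc(Cl)cc3)nn(CC(=O)Nc3ccc(Br)cc3)c2=O)cc1` likewise gives > 50000 nM in this assay, again a limit. Within the data shown here, the only measured step, a step that the two limits leave unreadable from compound 1 to compound 2, is therefore unreadable, both values sitting at the limit of > 50000 nM in this assay, at which 2 of the 2 values shown sit. Compound 3 `COc1ccc(Cc2cc(-c3ccc(C)cc3)nn(CC(=O)Nc3ccc(Br)cc3)c2=O)cc1` differs from compound 2 by methyl in place of chloro on an aromatic carbon. No readable step bears on this change, and compound 2 stands only at a limit. Compound 3 is expected to remain at that limit, an estimated step that the limit leaves unreadable from compound 2 to compound 3. The estimate for compound 3 is 80000 nM, range 20000 nM to 300000 nM.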

Compound 3, half-maximal effective concentration: > 50000 nM
Compound 3: only a limit was reported; the forecaster's own chance of this, stated with the estimate: 85%; the middle value does not contradict the limit.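

Among these compounds, compound 3 joins compound 1 and compound 2 at a limit, so no step among the three can be read: the limit of > 50000 nM in this assay, at which 3 of the 3 values shown sit. Left open is whether any group at this place on the shared core gives a measurable value in this assay.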